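The source may hold more compounds than are shown below. What is called first, only, known or untested is meant among the compounds shown, and "the series" means these compounds.

Measured so far in a functional assay on the whole organism (strain Sprague-Dawley CD) for inhibition, with Rattus norvegicus as the target, read by paw edema, at a dose of 30 mg/kg by the oral route; on this read-out higher numbers stand for a stronger effect at the one dose given and lower numbers for a weaker effect:
compound 1, `CCOC(=O)C(=O)Nc1cccccc1=O`: 79%
compound 2, `CCOC(=O)C(=O)Nc1c(C)ccccc1=O`: 4%
compound 3, `CCOC(=O)C(=O)Nc1ccccc(OC)c1=O`: 59%

Compound 1 stands highest of the three; its nearest neighbour is compound 3, and compound 2 lies furthest below it. Both known steps alter the ring of the shared core: a number 75 percentage points lower from compound 1 to compound 2 (beyond the scatter) and a number 20 percentage points lower from compound 1 to compound 3 (beyond the scatter). Compound 4, `CC(C)OC(=O)C(=O)Nc1cccccc1=O`, is not yet measured and differs from compound 1 elsewhere: methyl in place of hydrogen on a saturated chain carbon bound to an oxygen next to a carbonyl group and a saturated chain carbon, which cut one bond further out reads ethyl to isopropyl. Neither ring step speaks directly to a change on the chain, so the ring steps give only a loose guide; both went down, and the expectation is a small step down or none beyond the scatter in this assay. Compound 4 is therefore estimated at 65%, range 40% to 85%, which is expected to mean a number 14 percentage points lower from compound 1 to compound 4 (beyond the scatter).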

Compound 4, a percentage reported as inhibition, in the whole organism at one dose (the size of the read-out at that dose, not a potency): 63%
Compound 4: middle estimate off by 2 percentage points, on the high side, within the range that was stated.
By their numbers in this assay, from the lowest: compound 2; then compounds 3 and 4 (each within the scatter of the next); then compound 1.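

Among these compounds, this is the first change away from the ring, and it shows that the chain carbon bound to the oxygen is not neutral: in this assay, ethoxy to isopropoxy gives a number 16 percentage points lower from compound 1 to compound 4 (beyond the scatter). The single added methyl lowers the read-out without removing it, as compound 4 still gives 63%. No measurement at hand accounts for this drop.

Still open, on these data alone, is how a longer chain such as butoxy, or a carboxylic acid in place of the ethyl ester group, would read. Also open, as far as these compounds go, is how this chain change combines with the methoxy on the ring.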